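The compounds below may be only part of what the source reports. "The series", "measured", "known", "first", "only" and "open" are said of these compounds alone.

Among the compounds with values here, compound 1 `Cc1cc(Nc2cc(-c3ccccc3)[nH]n2)n2nc(SCc3ccc(Cl)cc3)nc2n1` gives 3950 nM in a functional assay on MGC-803 cells (Homo sapiens) for inhibition, read by MTT assay, with a stated time of 72 h (on this read-out higher numbers stand for weaker inhibition and lower numbers for stronger inhibition), the lowest of the three numbers so far. Compound 2 `CCCCCc1c(C)nc2nc(SCc3ccc(Cl)cc3)nn2c1Nc1cc(-c2ccccc2)[nH]n1` gives 7140 nM and compound 3 `Cc1ccc(Cn2ccc(Nc3cc(C)nc4nc(SCc5ccc(Br)cc5)nn34)n2)cc1` gives 7420 nM; both lie within the scatter of compound 1. Within the data shown here, the only single-site step, a 1.8-fold higher number from compound 1 to compound 2 (0.26 log units; within the scatter), concerns pentyl in place of hydrogen on an aromatic carbon and leaves the group on the sulfur untouched. Compound 4 `CCCSc1nc2nc(C)cc(Nc3cc(-c4ccccc4)[nH]n3)n2n1` is reached from compound 1 by ethyl in place of 4-chlorophenyl on a saturated chain carbon bound to a sulfur. Among the measured compounds shown here, no measured step alters this part of the shared core, and compound 3 differs from compound 1 in more than one place, so the change stands untested. Compound 4 is expected close to its parent, the step of a 1.4-fold higher number from compound 1 to compound 4 (0.14 log units; within the scatter) left open in direction, with an estimate of 5500 nM spanning 1800 nM to 17000 nM.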

Compound 4, half-maximal inhibitory concentration: 12600 nM
The estimate for compound 4 lay 2.3-fold (0.36 log units) below the measured number; the measured number falls inside the stated range.
By their numbers in this assay, from the lowest: compounds 1, 2, 3 and 4 (each within the scatter of the next, the first and the last beyond it).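

Swapping (4-chlorobenzyl)sulfanyl for propylsulfanyl gives the only single-site step beyond the scatter in this assay (a 3.2-fold higher number from compound 1 to compound 4 (0.50 log units; beyond the scatter)), though the step is modest. Within the data shown here, the group on the sulfur is therefore the one place so far where a single change registers, and the 4-chlorobenzyl form carries the lower number. Nothing measured here accounts for this difference. On these data alone, it remains open whether the aromatic ring or its chlorine drives the step. An unsubstituted benzyl or a longer chain such as hexyl on the sulfur would separate these readings.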